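This account rests on a few compounds, and the source may have more. Where it says the series, first, only, none or still open, it means among the compounds named here.

Measured so far in a functional assay on CCRF-CEM cells (Homo sapiens) for antiproliferative activity, read by MTT assay, with a stated time of 48 h, tested at 25 uM; on this read-out lower numbers stand for a stronger effect and higher numbers for a weaker effect at the one concentration tested:
Compound 1 `OC(CCn1nc2c(Br)c(Br)c(Br)c(Br)c2n1)c1ccc(Br)cc1`: 69%
Compound 2 `C[C@@H](O)CCn1nc2c(Br)c(Br)c(Br)c(Br)c2n1`: 71%

Compound 1 gives the lower of the two numbers, but compound 2, at 71%, lies within the usual scatter of it, so the two values show no real separation. Compound 3 `OC(CCn1nc2c(Br)c(Br)c(Br)c(Br)c2n1)c1cccc(Cl)c1` has not yet been measured. It differs from compound 1 in a single place: 3-chlorophenyl in place of 4-bromophenyl on a saturated chain carbon bound to an oxygen on a saturated carbon and a saturated chain carbon. Going by the values given here, no pair of measured compounds that differ in one place is available, so no measured step guides the move. With one substituted phenyl ring exchanged for another and the rest of the molecule unchanged, the step of a number 1 percentage points higher from compound 1 to compound 3 (within the scatter) is expected to stay within the scatter, with no clear direction. Because compound 1 gives 69% in this assay, compound 3 is estimated at 70%, with a range from 55% to 85%.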

Compound 3, a percentage reported as activity, at one concentration (the size of the read-out at that concentration, not a potency): 68%
Estimate against measurement, compound 3: 2 percentage points above; low and high end bracket the measured number.
By their numbers in this assay, from the lowest: compounds 3, 1 and 2 (each within the scatter of the next).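

In this assay, putting 3-chlorophenyl in place of 4-bromophenyl on a saturated chain carbon bound to an oxygen on a saturated carbon and a saturated chain carbon gives a number 1 percentage points lower from compound 1 to compound 3 (within the scatter). Going by these compounds alone, this is the first single-place step at this position, and it shows that the read-out does not separate these two halogen-bearing phenyl groups, although the halogen and its place on the ring change together, so neither change is read alone. No available evidence explains why the two compounds read alike.

On these data alone, whether the halogen or its place on the ring matters when changed alone remains open. So does whether an unsubstituted phenyl, a pyridine ring, an amine or a carboxylic acid at this position would give a number clearly apart from these.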